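From cyclohexyl to cycloheptyl on a shared core

The source may hold more compounds than are shown below. What is called first, only, known or untested is meant among the compounds shown, and "the series" means these compounds.

Measured so far in a physicochemical assay for solubility, measured as thermodynamic solubility, with a stated time of 24 h, at pH 6.8 (on this read-out higher numbers stand for higher solubility and lower numbers for lower solubility), are two compounds:
- compound 1 `Cc1cc(C)c2cc(C(=O)NC3CCCCC3)[nH]c2c1` gives < 4000 nM as a limit
- compound 2 `CCC(C)NC(=O)c1cc2c(C)cc(C)cc2[nH]1` gives 22000 nM as a number

Compound 1 gives < 4000 nM in this assay and this is a limit of the assay, not a number. Its standing is therefore the limit of < 4000 nM in this assay, at which 1 of the 2 values shown sits, and nothing more exact.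

Compound 3 `Cc1cc(C)c2cc(C(=O)NC3CCCCCC3)[nH]c2c1` has cycloheptyl in place of cyclohexyl on an amide-type nitrogen, a change counted as cycloheptyl in place of cyclohexyl on an amide-type nitrogen on the shared core of compound 1.

For the measured compounds named here, only one measured step bears on this change. That step is an at least 5.5-fold higher number from compound 1 to compound 2 (0.74 log units; beyond the scatter) and it has sec-butyl in place of cyclohexyl at the same amide-type nitrogen. Compound 3 moves the other way, to a larger ring, so no rise is expected, and a small fall is more likely. This rests on a single step whose size is itself only bounded. The expected change is a step that the limit leaves unreadable from compound 1 to compound 3 as a rough estimate. For compound 3 the estimated value is 2500 nM in this assay with an expected range from 800 nM to 5000 nM and a good chance of getting only a limit.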

Compound 3, solubility: < 4000 nM
Compound 3 ended at the assay's limit (the forecaster's own chance of this, stated with the estimate: 65%); the middle value lies beyond the limit too.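

In this assay, sec-butyl and cycloheptyl on the amide-type nitrogen of the shared core now stand clearly apart, with an at least 5.5-fold lower number from compound 2 to compound 3 (0.74 log units; beyond the scatter); a second ring, and not only cyclohexyl, therefore gives a lower number than the sec-butyl of compound 2. Cyclohexyl and cycloheptyl each carry a limit of the assay rather than a number, so the step between these two rings cannot be read, and whether the added ring carbon changes the read-out at all stays hidden. The low end of this assay now holds more than one compound: the limit of < 4000 nM in this assay, at which 2 of the 3 values shown sit.

For the compounds shown here, with only two rings and one chain on this nitrogen, the contrast between rings and the chain remains a comparison of very few compounds and cannot yet be called a pattern. Still open, going by these compounds, is whether a smaller carbon ring such as cyclobutyl, or a ring carrying an amine such as piperidinyl, would bring the shared core back to a readable number in this assay and so show how far the ring itself matters.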